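Adding a Fluoro Group to the Oxime of Compound 2

The source may report more compounds than this note shows. Statements on the series, on what has been measured and on what is new or still open speak of the compounds shown alone.

In a functional assay on the whole organism (strain Swiss albino) for inhibition, with Mus musculus as the target, in the writhing test, with a stated time of 30 min, at a dose of 5 mg/kg by the oral route (on this read-out lower numbers stand for a weaker effect and higher numbers for a stronger effect at the one dose given), compound 2 `Cc1c(/C=N\O)cc(-c2ccc(S(C)(=O)=O)cc2)n1-c1ccc(F)cc1` gives 2%, the lowest of the two numbers recorded. Among the measured compounds shown here, the only other measured compound, compound 1 `Cc1c(C=O)cc(-c2ccc(S(C)(=O)=O)cc2)n1-c1ccc(F)c(F)c1`, gives 50% in this assay , a number well beyond the scatter above it; since compound 1 differs from compound 2 in more than one place, no single step between them can be drawn, and the two values are reported only as they stand. Compound 3 `Cc1c(/C=N\O)cc(-c2ccc(S(C)(=O)=O)cc2)n1-c1ccc(F)c(F)c1` has not yet been measured in this assay . It differs from compound 2 by one change: fluoro in place of hydrogen on an aromatic carbon. Because compound 2 sits at 2%, the step expected from compound 2 to compound 3 in this assay is a modest rise of a number 13 percentage points higher from compound 2 to compound 3 (beyond the scatter), with no assurance that it clears the scatter. Compound 3 is therefore estimated at 15%, in a range from 0% to 45%.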

Compound 3, a percentage reported as inhibition, in the whole organism at one dose (the size of the read-out at that dose, not a potency): 10%
Compound 3: the middle estimate sits 5 percentage points above what was measured; measured number inside the range.
By their numbers in this assay, from the lowest: compounds 2 and 3 (each within the scatter of the next); then compound 1.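

In this assay, the change from 4-fluorophenyl to 3,4-difluorophenyl gives a number 8 percentage points higher from compound 2 to compound 3 (within the scatter), so this fluoro, placed ortho to a fluoro group and meta to a large group, does not separate the two compounds on this read-out. The change in the other place, a group of 3 heavy atoms in place of a group of 2 heavy atoms on an aromatic carbon, gives a number 40 percentage points lower from compound 1 to compound 3 (beyond the scatter), and this is the first single change shown to carry a large step. Nothing given here explains the size of either step.

The compounds shown leave open how a chloro or a methoxy group on that same aromatic carbon would read. They also leave open how an amine or a carboxylic acid would read in place of the group carried by compound 1 and compound 3.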